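Acid to methyl ester in a diyne cytotoxicity series

This account rests on a few compounds, and the source may have more. Where it says the series, first, only, none or still open, it means among the compounds named here.

Measured so far:
compound 1, `C=CCCCCCCCC#CC#CCO`: 3.32 ug/mL
compound 2, `C=CCCCCCCCC#CC#CCOCC(=O)O`: 4.47 ug/mL

Among the compounds with values here, in a functional assay on HCT-15 cells (Homo sapiens) for cytotoxicity (on this read-out lower numbers stand for an effect already at smaller amounts and higher numbers for an effect only at larger amounts of compound), compound 2 stands highest of the two numbers, but its only neighbour is compound 1, and the step of a 1.3-fold higher number from compound 1 to compound 2 (0.13 log units; within the scatter) lies within the scatter. Compound 3, `C=CCCCCCCCC#CC#CCOCC(=O)OC`, differs from compound 2 by methyl in place of hydrogen on an oxygen next to a carbonyl group. Within the data shown here, the one measured step that bears on it, a 1.3-fold higher number from compound 1 to compound 2 (0.13 log units; within the scatter), replaced hydrogen with carboxymethyl and moved nothing beyond the scatter. The further change from carboxy to methoxycarbonyl is therefore expected to give a step of a 1.3-fold lower number from compound 2 to compound 3 (0.11 log units; within the scatter) that stays within the scatter. Compound 3 is estimated at 3.5 ug/mL, with a range of 1.5 ug/mL to 8 ug/mL.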

Compound 3, concentration for half-maximal effect: > 30 ug/mL
Compound 3: no number, only a limit; the forecaster's own chance of this, stated with the estimate: 5%; middle value at least 8.5-fold (0.93 log units) from the limit.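

In this assay compound 3 gives only a limit, > 30 ug/mL, and no number: the limit of > 30 ug/mL in this assay, at which 1 of the 3 values shown sits. Methyl in place of hydrogen on an oxygen next to a carbonyl group gives an at least 6.7-fold higher number from compound 2 to compound 3 (0.82 log units; beyond the scatter), so this small change at the acid end moves the read-out where carboxymethyl did not. On the oxygen on a saturated carbon, (methoxycarbonyl)methyl gives an at least 9.0-fold higher number from compound 1 to compound 3 (0.95 log units; beyond the scatter), against a 1.3-fold higher number from compound 1 to compound 2 (0.13 log units; within the scatter) for carboxymethyl.

As far as these compounds go, whether an ethyl ester or a primary amide in place of the methyl ester goes the same way stays open. From the compounds shown here alone, the true size of both new steps also stays open, with only a limit for compound 3.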